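This account rests on a few compounds, and the source may have more. Where it says the series, first, only, none or still open, it means among the compounds named here.

Compound 1 `Nc1ccc(-c2cc(=O)c3c(N)c(F)c(CO)c(F)c3o2)cc1F` gives 62 nM in a functional assay on MCF7 cells (Homo sapiens) for cytotoxicity, read by neutral red uptake, with a stated time of 3 days (on this read-out higher numbers stand for weaker inhibition and lower numbers for stronger inhibition), the lowest of the three numbers in hand. Compound 2 `[N-]=[N+]=Nc1c(F)c(N)c2c(=O)cc(-c3ccc(N)c(F)c3)oc2c1F` gives 460 nM and compound 3 `CCOC(=O)c1c(F)c(N)c2c(=O)cc(-c3ccc(N)c(F)c3)oc2c1F` gives 1400 nM; each replaces the hydroxymethyl of compound 1 outright, with a 7.4-fold higher number from compound 1 to compound 2 (0.87 log units; beyond the scatter) and a 23-fold higher number from compound 1 to compound 3 (1.35 log units; beyond the scatter). Compound 4 `CN(C)CCCC(=O)OCc1c(F)c(N)c2c(=O)cc(-c3ccc(N)c(F)c3)oc2c1F` instead keeps that hydroxymethyl and extends it: (3-(dimethylamino)propyl)carbonyl in place of hydrogen on an oxygen on a saturated carbon. Among the compounds with values here, no measured step alters this oxygen while keeping its saturated carbon, so the two steps from compound 1 only show that changes at this part of the shared core have weakened inhibition. A small to modest weakening is therefore expected, a 2.4-fold higher number from compound 1 to compound 4 (0.38 log units; beyond the scatter). Compound 4 is estimated at 150 nM in this assay, within a range of 40 nM to 600 nM.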

Compound 4, half-maximal inhibitory concentration: 29 nM
Compound 4: the middle estimate sits 5.2-fold (0.71 log units) above what was measured; measured number outside the range, below it.
By their numbers in this assay, from the lowest: compound 4; then compound 1; then compound 2; then compound 3.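

Earlier changes at this aromatic carbon removed the hydroxymethyl and weakened inhibition, but keeping it and adding (3-(dimethylamino)propyl)carbonyl on its oxygen strengthens inhibition in this assay, with a 2.1-fold lower number from compound 1 to compound 4 (0.33 log units; beyond the scatter). This added chain is therefore accepted on the oxygen, and the gaps to the outright replacements are large, with a 48-fold lower number from compound 3 to compound 4 (1.68 log units; beyond the scatter) and a 16-fold lower number from compound 2 to compound 4 (1.20 log units; beyond the scatter). Nothing available explains this gain. As far as these compounds go, it remains open whether the gain needs the terminal dimethylamino group, or whether a plain acetyl group or a longer chain ending in a morpholine on this oxygen would do the same.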